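A few compounds are considered here, and "the series" means these few. Any claim that something is new, unique, unknown or untested is made for them only; others in the source may bear on it.

Measured so far:
compound 1 `CC[C@H](Nc1c(C#N)c(-c2ccc(Br)cc2)nc2cnccc12)C(N)=O` — 2.3
compound 2 `CC[C@@H](Nc1c(C#N)c(-c2ccc(-c3cnccc3C)cc2)nc2cnccc12)C(N)=O` — 2

In a physicochemical assay for lipophilicity, read by HPLC, at pH 7.5 (a lower number here means a more polar compound, a higher number a more lipophilic compound), compound 2 gives 2, the lower of the two numbers in hand; compound 1 gives 2.3, and the gap between the two is within the scatter of repeated measurements, so the two are read as alike. For the measured compounds named here, no step between measured compounds is available.

Compound 3 `CC[C@@H](Nc1c(C#N)c(-c2ccc(-c3ccccc3Cl)cc2)nc2cnccc12)C(N)=O` differs from compound 2 in one place: 2-chlorophenyl in place of 4-methylpyridin-3-yl on an aromatic carbon. The group that leaves carries one hydrogen-bond acceptor; the group that enters carries none. Going by the values given here, with no measured step of this kind, only a direction is ventured: a shift upward in this assay is expected, most likely beyond the scatter.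

Estimate for compound 3: 2.9, with a range from 2.4 to 3.4; this means an expected step of a number 0.90 log units higher from compound 2 to compound 3 (beyond the scatter).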

Compound 3, distribution coefficient: 2.9
Beside the measured number, compound 3's estimate shows no gap at the digits printed; the measured number falls inside the stated range.
By their numbers in this assay, from the lowest: compounds 2 and 1 (each within the scatter of the next); then compound 3.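

At this aromatic carbon, para to a large group, the number in this assay depends on which ring is attached: 2-chlorophenyl in place of 4-methylpyridin-3-yl gives a number 0.90 log units higher from compound 2 to compound 3 (beyond the scatter) at this place, a modest step. Both groups have the same heavy-atom count and one six-membered aromatic ring, so the step arises without a change in that count, while the hydrogen-bond acceptor count of the group falls to none. No measurement of any property of these groups is available to explain the step.

The compounds shown leave open how the step divides among the ring nitrogen, the methyl and the chlorine, which plain phenyl or 4-chlorophenyl at this place could help to separate. Going by these compounds, how this assay responds here to an attached amine or carboxylic acid also remains open.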